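This account rests on a few compounds, and the source may have more. Where it says the series, first, only, none or still open, it means among the compounds named here.

Two compounds from this series have been examined in an assay for positive allosteric modulation of metabotropic glutamate receptor 3 (Rattus norvegicus); a higher number here means that more compound is needed for the effect, a lower number that less compound is needed. Compound 1 `COC(=O)c1cc(OCCCCOc2ccc(C(=O)CC(C)(C)C)c(O)c2C)ccc1F` is reported in this assay as "not active" (no number reported), with no number given. Going by the values given here, compound 2 `Cc1cc(C(=O)O)ccc1OC[C@H](C)COc1ccc(C(=O)CC(C)(C)C)c(O)c1C` gives 1520 nM in this assay, and this is the only number available, so compound 2 has no measured neighbour against which to judge its standing. Compound 3 `COc1ccccc1OC[C@H](C)COc1ccc(C(=O)CC(C)(C)C)c(O)c1C` is not yet measured. Compared with compound 2 it differs in one place: 2-methoxyphenyl in place of 4-carboxy-2-methylphenyl on an oxygen on a saturated carbon. Among the compounds with values here, no step between measured compounds covers a change of this kind, and the outcome for compound 1 gives no number to lean on. The expectation for compound 3 is that the step of a 3.9-fold higher number from compound 2 to compound 3 (0.60 log units; beyond the scatter) goes toward a larger concentration, beyond the usual scatter, with a real chance that no number is reported at all. For compound 3 the estimated value in this assay is 6000 nM, within a range from 1500 nM to 25000 nM.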

Compound 3, half-maximal effective concentration: "not active" (no number reported)
Compound 3 has no reported number here, so the estimate cannot be set against anything.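

Going by these compounds alone, compound 3 has no number, so no step from compound 2 to compound 3 can be read. No measurement shown here accounts for this outcome. Still open, going by these compounds, is which part of the swap from 4-carboxy-2-methylphenyl to 2-methoxyphenyl separates compound 2 from compound 3.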